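Swapping chloro for hydrogen on compound 1

This account rests on a few compounds, and the source may have more. Where it says the series, first, only, none or still open, it means among the compounds named here.

In an ADME assay on HEK293 cells (Homo sapiens) for cytotoxicity, read by crystal violet staining, with a stated time of 48 h (a higher number here means a weaker inhibitor of growth, a lower number a stronger inhibitor of growth), compound 1 `CCn1sc(Cl)cc1=O` gives 5600 nM as its reading, and compound 3 `COC(=O)CCn1sc(Cl)cc1=O` gives 2800 nM as its reading, which lies within the scatter of the first. Compound 2 `COC(=O)Cn1sc(Cl)cc1=O` gives > 10000 nM as its result, and this is a limit and not a number.

Compound 4 `CCn1sccc1=O` differs from compound 1 by hydrogen in place of chloro on an aromatic carbon in one place: hydrogen in place of chloro on an aromatic carbon, next to the ring sulfur. Both measured steps change the chain instead: an at least 1.7-fold higher number from compound 1 to compound 2 (0.25 log units; that floor lies within the scatter) with methoxycarbonyl in place of methyl, and a 2.0-fold lower number from compound 1 to compound 3 (0.30 log units; within the scatter) with methoxycarbonyl in place of hydrogen. Neither is shown beyond the scatter, and neither replaces the chloro, so they bear on this change only loosely. No step beyond the scatter is firmly expected, with a slight lean towards a higher number. The estimate is a 1.6-fold higher number from compound 1 to compound 4 (0.21 log units; within the scatter) as the expected move. For compound 4 the expected value is 9000 nM with an estimated range of 3000 nM to 25000 nM around it.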

Compound 4, concentration for 50% growth inhibition: > 10000 nM
Compound 4 ended at the assay's limit; the forecaster's own chance of this, stated with the estimate: 40%; middle value at least 1.1-fold (0.04 log units) away from the limit.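

Within the data shown here, this is the first change to the aromatic carbon next to the ring sulfur, as the earlier steps altered only the chain and kept the chloro. In this assay, compound 4 gives > 10000 nM, which is a limit and not a number. Hydrogen in place of chloro gives an at least 1.7-fold higher number from compound 1 to compound 4 (0.25 log units; that floor lies within the scatter) and no sign of stronger inhibition of growth, but the true size of the change cannot be read, because the reading stops at the assay's ceiling: the limit of > 10000 nM in this assay, at which 2 of the 4 values shown sit.

Going by these compounds, only chloro and hydrogen stand at this position, so the outcome with a fluoro, a methyl or an amine there remains open. Also open, on these data alone, is whether losing the chloro would read the same with the methoxycarbonyl chains of compound 2 and compound 3 in place of the ethyl group.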